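Removing a Methyl Group on a Shared Core, Twice

This account rests on a few compounds, and the source may have more. Where it says the series, first, only, none or still open, it means among the compounds named here.

Compound 1 `COc1cc(OC)c2c(=O)n(-c3ccccc3)ccc2c1` and compound 2 `COc1cc(O)c2c(=O)n(-c3ccccc3)ccc2c1` form one pair; compound 3 `C=CC(=O)Nc1c(OC)cc(OC)c2c(=O)n(-c3cccc(C(=O)N4CCCCC4)c3)ccc12` and the not yet measured compound 4 `C=CC(=O)Nc1c(OC)cc(O)c2c(=O)n(-c3cccc(C(=O)N4CCCCC4)c3)ccc12` form the other. The difference between the two cores is not broken down here. Within each pair the change is the same: hydrogen in place of methyl on an oxygen on an aromatic ring and (hydrogen in place of methyl on an oxygen on an aromatic ring).

In a functional assay on A549 cells (Homo sapiens) for antiproliferative activity, read by MTT assay, with a stated time of 72 h (on this read-out higher numbers stand for weaker inhibition and lower numbers for stronger inhibition), compound 1 gives 44500 nM and compound 2 gives 27900 nM, a step of a 1.6-fold lower number from compound 1 to compound 2 (0.20 log units; within the scatter). In this assay compound 3 gives 14700 nM, which stands nearest to the number of compound 2 and further from that of compound 1.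

Compound 4 is expected to show a step of a 1.5-fold lower number from compound 3 to compound 4 (0.17 log units; within the scatter) because the earlier pair gave a 1.6-fold lower number from compound 1 to compound 2 (0.20 log units; within the scatter). Compound 4 is therefore estimated at 10000 nM, between 4000 nM and 25000 nM in this assay.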

Compound 4, half-maximal inhibitory concentration: 14700 nM
Compound 4: middle estimate off by 1.5-fold (0.17 log units), on the low side; low and high end bracket the measured number.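

In this assay, the change from methoxy to hydroxy on the second core reads no change at the digits printed from compound 3 to compound 4 (within the scatter). Set beside the first pair, the change carries across the two cores without a difference that can be told from the scatter: the same change on two cores in this assay, a 1.6-fold lower number (0.20 log units; within the scatter) from compound 1 to compound 2 and no change at the digits printed (within the scatter) from compound 3 to compound 4, 1.6-fold (0.20 log units) apart, within the scatter of two such steps This shows that neither step exceeds the scatter and that the two steps agree, but with only two pairs and steps this small, it does not show that the change has no effect, nor that the agreement would hold on any other core or in another read-out.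

The compounds shown leave open what a longer chain on that oxygen, such as ethyl, or an amine in place of the hydroxy would do to the number.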